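This account rests on a few compounds, and the source may have more. Where it says the series, first, only, none or still open, it means among the compounds named here.

In a functional assay on HEK293 cells for agonist activity at Bombesin receptor subtype-3 (Mus musculus), read by luminescence and calcium flux, with a stated time of 10 min (on this read-out higher numbers stand for an effect only at larger amounts of compound and lower numbers for an effect already at smaller amounts), compound 1 `CCC(C)(C)Cc1c[nH]c(CCc2ccc(-n3cccn3)cc2)n1` gives 9 nM, which places it second highest of the three numbers shown. Compound 3 `CCC(C)(C)Cc1c[nH]c(CCc2ccc(-c3cccc(N)n3)cc2)n1` gives 3.9 nM in this assay, and compound 2 `CCC(C)(C)Cc1c[nH]c(CCc2ccc(-n3ncnn3)cc2)n1` gives 25 nM. Compound 4 `CCC(C)(C)Cc1c[nH]c(CCc2ccc(-c3cccnc3)cc2)n1` has not yet been measured; it differs from compound 1 at a single place: pyridin-3-yl in place of 1H-pyrazol-1-yl on an aromatic carbon. Two measured steps start from compound 1 and change the same group. The step of a 2.8-fold higher number from compound 1 to compound 2 (0.44 log units; beyond the scatter) went in one direction, and the step of a 2.3-fold lower number from compound 1 to compound 3 (0.36 log units; beyond the scatter) went in the other, each modest. Neither step puts a plain pyridin-3-yl in place; compound 3 carries an amino group on its ring, and compound 2 keeps a five-membered ring. Both known steps are modest, so a modest step is expected in this assay for compound 4, its direction uncertain, and the estimate leans toward a slightly higher number because the amino group that accompanied the lower number in compound 3 3.9 nM is absent. Compound 4 is therefore estimated at 15 nM, within a range from 5 nM to 45 nM, a step of a 1.7-fold higher number from compound 1 to compound 4 (0.22 log units; within the scatter).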

Compound 4, half-maximal effective concentration: 4.3 nM
The estimate for compound 4 lay 3.5-fold (0.54 log units) above the measured number; the measured number lies below the stated range.
By their numbers in this assay, from the lowest: compounds 3 and 4 (each within the scatter of the next); then compound 1; then compound 2.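

In this assay, putting pyridin-3-yl in place of 1H-pyrazol-1-yl gave a 2.1-fold lower number from compound 1 to compound 4 (0.32 log units; beyond the scatter) and showed that this position accepts a six-membered aromatic ring with no amino group and still gives a low number. Compound 4 carries no amino group, and yet the comparison with the aminopyridine shows a 1.1-fold higher number from compound 3 to compound 4 (0.04 log units; within the scatter) and stays within the scatter, so among these compounds the amino group is not required for a number this low. Against the tetrazole the change gave a 5.8-fold lower number from compound 2 to compound 4 (0.76 log units; beyond the scatter) and leaves both six-membered rings with lower numbers than either five-membered ring among these four groups. On these data alone, whether a phenyl ring, or a pyridin-3-yl bearing an amine or a carboxylic acid, would fit the same pattern remains open. The compounds shown offer no evidence on why these groups differ.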